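Two Measured Compounds and a Third Awaiting Its Number

The compounds below may be only part of what the source reports. "The series", "measured", "known", "first", "only" and "open" are said of these compounds alone.

Compound 1 `N#CCC(=O)N/N=C1\C(=O)Nc2ccc(S(=O)(=O)N3CCOCC3)cc21`: 27700 nM
Compound 2 `O=C1Nc2ccc(S(=O)(=O)N3CCOCC3)cc2/C1=N/c1ccc(/N=C2\C(=O)Nc3ccc(S(=O)(=O)N4CCOCC4)cc32)cc1`: 10900 nM

In a functional assay on MCF7 cells (Homo sapiens) for cytotoxicity, read by sulforhodamine B assay, with a stated time of 24 h (on this read-out lower numbers stand for stronger inhibition and higher numbers for weaker inhibition), compound 1 gives 27700 nM, the highest of the two numbers. Compound 2 gives 10900 nM, a gap beyond the usual scatter. Compound 3 `Cc1ccc(/N=C2\C(=O)Nc3ccc(S(=O)(=O)N4CCOCC4)cc32)cc1` differs from compound 1 by 4-methylphenyl in place of ((cyanomethyl)carbonyl)amino on a double-bonded nitrogen. Among the compounds with values here, no step between measured compounds tells what this change does. A modest downward step a 2.1-fold lower number from compound 1 to compound 3 (0.33 log units; beyond the scatter) is expected, because compound 2 gives 10900 nM while also carrying an aromatic ring on that nitrogen. Compound 3 is therefore estimated at 13000 nM, with a range from 4500 nM to 38000 nM.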

Compound 3, half-maximal inhibitory concentration: 55900 nM
Beside the measured number, compound 3's estimate is 4.3-fold (0.63 log units) below it, and the stated range ends below it.
By their numbers in this assay, from the lowest: compound 2; then compounds 1 and 3 (each within the scatter of the next).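

In this assay, putting 4-methylphenyl in place of ((cyanomethyl)carbonyl)amino on the double-bonded nitrogen gives a 2.0-fold higher number from compound 1 to compound 3 (0.30 log units; within the scatter), so this exchange of an open chain for an aromatic ring moves the read-out by no more than the scatter. An aromatic ring at this position therefore does not, on its own, set compound 3 apart from compound 1. No measurement shown accounts for this result. Still open, from the compounds shown here alone, is whether a carboxylic acid or an amine in place of the methyl on that ring would shift the number beyond the scatter.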